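A few compounds are considered here, and "the series" means these few. Any claim that something is new, unique, unknown or untested is made for them only; others in the source may bear on it.

Measured in a functional assay on HCT-116 cells (Homo sapiens) for inhibition, read by MTT assay, with a stated time of 72 h; on this read-out lower numbers stand for stronger inhibition and higher numbers for weaker inhibition:
- compound 1 `CCN1CCN(Cc2c(OC)cc(Oc3cccc(Nc4ccccc4)c3)cc2OC)CC1`: > 20000 nM (a limit)
- compound 2 `COc1cc(Oc2cccc(Nc3ccccc3)c2)cc(OC)c1CN(C)C`: 12900 nM
- compound 3 `COc1cc(Oc2cccc(Nc3ccccc3)c2)cc(OC)c1CCO`: > 20000 nM (a limit)

Compound 3 has no number, only the limit > 20000 nM. The data so far are thin, with the limit of > 20000 nM in this assay, at which 2 of the 3 values shown sit.

Compound 4 `COc1cc(Oc2cccc(Nc3ccccc3)c2)cc(OC)c1CNC1CC1` carries cyclopropylamino in place of hydroxymethyl on a saturated chain carbon bound to an aromatic carbon.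

The closest measured change is an at least 1.5-fold higher number from compound 2 to compound 3 (0.19 log units; that floor lies within the scatter), where hydroxymethyl replaces dimethylamino. The change at the same place in an at least 1.5-fold lower number from compound 1 to compound 2 (0.19 log units; that floor lies within the scatter) also has a floor within the scatter, and a step that the two limits leave unreadable from compound 1 to compound 3 cannot be read. Neither readable step therefore shows a change beyond the scatter. Among the measured compounds shown here, compound 2, with dimethylamino, is the only compound with a number, at 12900 nM, so it serves as the anchor.

A small move to a lower number in this assay is expected, with a real chance of another limit: an at least 1.6-fold lower number from compound 3 to compound 4 (0.22 log units; that floor lies within the scatter). For compound 4 the estimated value is 12000 nM, with an expected range of 5000 nM to 25000 nM.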

Compound 4, half-maximal inhibitory concentration: > 20000 nM
Compound 4 was reported as a limit; the forecaster's own chance of this, stated with the estimate: 35%; middle value at least 1.6-fold (0.22 log units) from the limit.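

Cyclopropylamino on this saturated chain carbon bound to an aromatic carbon leaves compound 2 as the only compound with a number in this assay, at 12900 nM. Among the compounds shown here, the one readable step, an at least 1.5-fold higher number from compound 2 to compound 4 (0.19 log units; that floor lies within the scatter), shows no sure change beyond the scatter when cyclopropylamino replaces dimethylamino. The other steps to compound 4 join two limits and cannot be read, and compound 1 and compound 4 both carry an amine at this place yet give only a limit, so an amine here does not by itself yield a number: the limit of > 20000 nM in this assay, at which 3 of the 4 values shown sit.

Still open, on these data alone, is whether a smaller amine such as methylamino, a carboxylic acid or a longer chain on this carbon would give a value clearly beyond the scatter from compound 2. As far as these compounds go, how far the limit compounds actually lie from one another also remains unknown.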